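This account rests on a few compounds, and the source may have more. Where it says the series, first, only, none or still open, it means among the compounds named here.

In an ADME assay on L1210/0 cells (Mus musculus) for cytotoxicity, with a stated time of 48 h (on this read-out lower numbers stand for stronger inhibition and higher numbers for weaker inhibition), the series begins with compound 1 `C=C(Br)[C@H]1O[C@@H](n2cnc3c(N)ncnc32)[C@@H](O)[C@H]1O`, which gives 25000 nM, and compound 2 `CC1=C(C)C(=O)C(c2cn([C@H]3C[C@H](O)[C@@H](CO)O3)c(=O)[nH]c2=O)=CC1=O`, which gives 112000 nM. Compound 3 `N#Cc1cn([C@H]2C[C@H](O)[C@@H](CO)O2)c(=O)[nH]c1=O` stands apart from both: in this assay compound 3 records only a limit, > 200000 nM, and no number. That limit is the one described by the limit of > 200000 nM in this assay, at which 1 of the 3 values shown sits, so compound 3 stands at the top of the values shown, where the assay reports nothing more.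

The step to compound 4 `CCCc1cn([C@H]2C[C@H](O)[C@@H](CO)O2)c(=O)[nH]c1=O` changes a single position: propyl in place of cyano on an aromatic carbon.

Among the measured compounds shown here, with no measured step of this kind, the size and direction of the change to compound 4 remain open. Compound 4 is estimated to fall near 150000 nM, within 40000 nM to 400000 nM, which corresponds to an expected step of an at least 1.3-fold lower number from compound 3 to compound 4 (0.12 log units; that floor lies within the scatter). Since compound 3 gave only a limit, compound 4 may well also be reported as a limit rather than a number.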

Compound 4, half-maximal inhibitory concentration: > 200000 nM
Compound 4 was reported as a limit (the forecaster's own chance of this, stated with the estimate: 55%); at least 1.3-fold (0.12 log units) between middle value and limit.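

Compound 3 and compound 4 both end at a limit of the assay rather than a number, so no step can be read between them: the limit of > 200000 nM in this assay, at which 2 of the 4 values shown sit. The compounds shown leave open how large a change, and in which direction, propyl in place of cyano on an aromatic carbon makes in this assay.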